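Piperidine substituent series: furan-2-yl to 4-methoxyphenyl

A few compounds are considered here, and "the series" means these few. Any claim that something is new, unique, unknown or untested is made for them only; others in the source may bear on it.

Measured compounds:
compound 1 `Cc1ccc2c(NCc3ccc(NC(=O)C4CCN(C5CCCCC5)CC4)cc3)nc(N(C)C)nc2c1`: in a functional assay on SV5A8 cells (Homo sapiens) for cytotoxicity (a lower number here means a stronger inhibitor, a higher number a weaker inhibitor), compound 1 gives > 8320 nM, which is a limit of the assay.
compound 2 `Cc1ccc2c(NCc3ccc(NC(=O)C4CCN(Cc5ccco5)CC4)cc3)nc(N(C)C)nc2c1`: in this assay compound 2 gives > 20000 nM, which is also a limit of the assay.

Compound 2 stands at the less-potent end of what these numbers show, though only as a limit; the other value shown is a limit as well. The step from compound 1 to compound 2, a step that the two limits leave unreadable from compound 1 to compound 2, therefore cannot be read in size or direction, since the limit of > 20000 nM in this assay, at which 1 of the 2 values shown sits, and the limit of > 8320 nM in this assay, at which 1 of the 2 values shown sits, are the only two points available.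

Compound 3 `COc1ccc(CN2CCC(C(=O)Nc3ccc(CNc4nc(N(C)C)nc5cc(C)ccc45)cc3)CC2)cc1` differs from compound 2 as follows: 4-methoxyphenyl in place of furan-2-yl on a saturated chain carbon bound to an amine nitrogen in a ring.

No measured step bears on this change directly, and the one step shown is unreadable. With both neighbours at limits, no shift beyond the scatter can be expected from the step that the limit leaves unreadable from compound 2 to compound 3 in this assay; the estimate for compound 3 is 25000 nM, within 8000 nM to 80000 nM, most likely reported again as a limit.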

Compound 3, half-maximal inhibitory concentration: > 6180 nM
Compound 3: a limit, no number; the forecaster's own chance of this, stated with the estimate: 80%; the middle value lies beyond the limit too.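

In this assay compound 3 gives > 6180 nM, which is a limit of the assay. With compound 1 and compound 2 also reported only as limits, no step among these three compounds can be read. Left open is whether cyclohexyl, (furan-2-yl)methyl and 4-methoxybenzyl on an amine nitrogen in a ring differ at all in this read-out.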